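A few compounds are considered here, and "the series" means these few. Any claim that something is new, unique, unknown or untested is made for them only; others in the source may bear on it.

In a functional assay on A549 cells (Homo sapiens) for antiproliferative activity, read by MTT assay, with a stated time of 72 h (on this read-out higher numbers stand for weaker inhibition and lower numbers for stronger inhibition), compound 3 `CCOc1ccc(NC2=C(C(=O)c3ccccc3)C(c3ccc(Br)cc3)N(CCCn3ccnc3)C2=O)cc1` gives 20200 nM. Compound 1 `CCOC1=C(C(=O)c2ccccc2)C(c2ccc(Br)cc2)N(CCCn2ccnc2)C1=O` gives 35300 nM and compound 2 `O=C(C1=C(Nc2ccccc2)C(=O)N(CCCn2ccnc2)C1c1ccc(Br)cc1)c1ccccc1` gives 24100 nM, so all three sit close together: the steps of a 1.5-fold lower number from compound 1 to compound 2 (0.17 log units; within the scatter), a 1.7-fold lower number from compound 1 to compound 3 (0.24 log units; within the scatter) and a 1.2-fold lower number from compound 2 to compound 3 (0.08 log units; within the scatter) each stay within the scatter, and compound 3 cannot be set apart from the other two. Compound 4 `O=C(C1=C(Nc2ccc(OC(F)(F)F)cc2)C(=O)N(CCCn2ccnc2)C1c1ccc(Br)cc1)c1ccccc1` differs from compound 3 by trifluoromethyl in place of ethyl on an oxygen on an aromatic ring. Within the data shown here, no measured step swaps these two groups; the nearest comparison, a 1.2-fold lower number from compound 2 to compound 3 (0.08 log units; within the scatter), put ethoxy onto the same ring and moved the number only within the scatter, so a step of a 1.0-fold lower number from compound 3 to compound 4 (0.00 log units; within the scatter) is expected, nothing beyond the scatter. Compound 4 is estimated at 20000 nM, within the range 8000 nM to 50000 nM.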

Compound 4, half-maximal inhibitory concentration: 20800 nM
Compound 4: middle estimate off by 1.0-fold (0.02 log units), on the low side, and the stated range covers the measured number.
By their numbers in this assay, from the lowest: compounds 3, 4, 2 and 1 (each within the scatter of the next).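

In this assay, trifluoromethyl on the oxygen cannot be told apart from ethyl (a 1.0-fold higher number from compound 3 to compound 4 (0.01 log units; within the scatter)), so this position accepts a fluorinated group as well as a purely carbon one with no step beyond the scatter. The trifluoromethoxy group likewise stays within the scatter against hydrogen on that aromatic carbon (a 1.2-fold lower number from compound 2 to compound 4 (0.06 log units; within the scatter)), and the whole (4-(trifluoromethoxy)phenyl)amino group does so against ethoxy on the double-bonded ring carbon (a 1.7-fold lower number from compound 1 to compound 4 (0.23 log units; within the scatter)). Nothing available here explains this flat result. As far as these compounds go, whether an amine or a carboxylic acid on the same aromatic ring would give a step beyond the scatter stays open.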